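The source may hold more compounds than are shown below. What is called first, only, known or untested is meant among the compounds shown, and "the series" means these compounds.

In a functional assay on the whole organism (strain Sprague-Dawley) for inhibition, with Rattus norvegicus as the target, read by paw edema, with a stated time of 180 min, at a dose of 30 mg/kg by the oral route (on this read-out higher numbers stand for a stronger effect at the one dose given and lower numbers for a weaker effect), compound 1 `COc1ccnc(CNc2ccc3c(c2)nc(C)n3C[C@@H](O)[C@H]2O[C@H](O)[C@@H](O)[C@H]2O)c1OC` gives 72% and compound 2 `COc1ccnc(CNc2ccc3[nH]c(C)nc3c2)c1C` gives 55%. Compound 2 stands lowest of the two numbers, its nearest neighbour being compound 1, which lies higher by more than the usual scatter. Compound 3 `COc1ccnc(CNc2ccc3[nH]c(C)nc3c2)c1OC` is not yet measured; it differs from compound 2 by methoxy in place of methyl on an aromatic carbon. Compound 1 also carries this methoxy pattern, but with a further substituent on its core, so the comparison is loose. A step of a number 7 percentage points higher from compound 2 to compound 3 (within the scatter) is expected, a small gain within the scatter. Compound 3 is expected to give 62%, within 45% to 78%.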

Compound 3, a percentage reported as inhibition, in the whole organism at one dose (the size of the read-out at that dose, not a potency): 61%
Compound 3: the middle estimate sits 1 percentage points above what was measured; the measured number falls inside the stated range.
By their numbers in this assay, from the lowest: compounds 2 and 3 (each within the scatter of the next); then compound 1.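

In this assay, methoxy in place of methyl on an aromatic carbon, ortho to a methoxy group and two atoms from the ring nitrogen, gives a number 6 percentage points higher from compound 2 to compound 3 (within the scatter), so the read-out at this position does not separate the two groups. The larger difference in the series lies elsewhere: a hydrogen atom in place of the group of 11 heavy atoms on the aromatic nitrogen gives a number 11 percentage points lower from compound 1 to compound 3 (beyond the scatter). No measurement available here bears on the reason for either step.

Open at this position is how an ethoxy group or an amine would read. Also open, from the compounds shown here alone, is whether a shorter chain, such as hydroxyethyl, on that nitrogen would match the larger group.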